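A few compounds are considered here, and "the series" means these few. Any claim that something is new, unique, unknown or untested is made for them only; others in the source may bear on it.

Measured so far:
compound 1 `COc1ccc(OC)c(-c2cc(-c3ccc(C(=O)N4CCCCC4)s3)on2)c1` — in a functional assay on PC-3 cells (Homo sapiens) for cytotoxicity, read by XTT assay, with a stated time of 72 h (a higher number here means a weaker inhibitor, a lower number a stronger inhibitor), compound 1 returns only the assay limit > 30000 nM.
compound 2 `COc1ccc(OC)c(-c2cc(-c3ccc(C(=O)NCC4CC4)s3)on2)c1` — compound 2 likewise sits at the limit > 30000 nM.
compound 3 `CCN(CC)C(=O)c1ccc(-c2cc(C3=CC(=O)C=CC3=O)no2)s1` — compound 3 gives 8900 nM.

For the measured compounds named here, compound 3 therefore holds the only numeric value in this assay; the other two entries are limits, as the limit of > 30000 nM in this assay, at which 2 of the 3 values shown sit, records. Compound 4 `CN(Cc1ccccc1)C(=O)c1ccc(-c2cc(C3=CC(=O)C=CC3=O)no2)s1` differs from compound 3 by benzyl(methyl)amino in place of diethylamino on a carbonyl carbon. Going by the values given here, the only step available, a step that the two limits leave unreadable from compound 1 to compound 2, is an amide substitution on the core of compound 1 and cannot be read from two limits, so no measured step bears on this change. The expected step of a 1.1-fold lower number from compound 3 to compound 4 (0.05 log units; within the scatter) is therefore none beyond the scatter. Compound 4 is estimated at 8000 nM, with a range from 3000 nM to 25000 nM.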

Compound 4, half-maximal inhibitory concentration: 11000 nM
The estimate for compound 4 lay 1.4-fold (0.14 log units) below the measured number; measured number inside the range.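

In this assay, benzyl(methyl)amino in place of diethylamino on a carbonyl carbon gives a 1.2-fold higher number from compound 3 to compound 4 (0.09 log units; within the scatter). For the compounds shown here, this is the first readable step at this amide, and the two amides cannot be told apart even though the entering group brings a six-membered aromatic ring of carbon only. The step on the core of compound 1 cannot be read, and limits remain in the series: the limit of > 30000 nM in this assay, at which 2 of the 4 values shown sit.

Open, on these data alone, is whether a piperazine or a carboxylic acid on this carbonyl carbon of the shared core moves the number beyond the scatter.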